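This account rests on a few compounds, and the source may have more. Where it says the series, first, only, none or still open, it means among the compounds named here.

Of the compounds shown here, three have so far been tested in an ADME assay on MDBK cells (Bos taurus) for cytotoxicity, read by MTT assay, with a stated time of 96 h; a lower number here means that less compound is tolerated, a higher number that more compound is tolerated. Compound 1 `FC(F)(F)c1cccc(NC(=S)Nc2ccc(I)cc2)c1` gives 9500 nM, compound 2 `O=[N+]([O-])c1ccc(NC(=S)Nc2cccc(C(F)(F)F)c2)cc1` gives 10000 nM and compound 3 `CCCC[C@H]1CC[C@H](c2ccc(NC(=S)Nc3cccc(C(F)(F)F)c3)cc2)CC1` gives 10000 nM. The numbers do not separate them, so compound 1 stands level with both of the others. The steps are a 1.1-fold higher number from compound 1 to compound 2 (0.02 log units; within the scatter), a 1.1-fold higher number from compound 1 to compound 3 (0.02 log units; within the scatter) and no change at the digits printed from compound 2 to compound 3 (within the scatter).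

Compound 4 `CCNC(=S)Nc1cccc(C(F)(F)F)c1` brings a different kind of change: ethyl in place of 4-iodophenyl on an amide-type nitrogen. This is ethyl in place of 4-iodophenyl on an amide-type nitrogen. The measured steps bear on it only in part. They exchange iodo, nitro and 4-butylcyclohexyl on an aromatic carbon, and the aromatic ring carrying those groups stays in every compound. Here that ring leaves along with the iodo, and no measured compound shows what such a loss does in this assay.

Among the compounds with values here, the only guide is the flatness of the three steps, even for a swap as large as a 1.1-fold higher number from compound 1 to compound 3 (0.02 log units; within the scatter). No step beyond the scatter is therefore expected, though with little confidence, and the range is left wider on the higher side. The expected step is a 1.3-fold higher number from compound 1 to compound 4 (0.10 log units; within the scatter). Compound 4 is estimated at 12000 nM, with an expected range from 5000 nM to 50000 nM.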

Compound 4, half-maximal cytotoxic concentration: > 100000 nM
Compound 4 ended at the assay's limit; the forecaster's own chance of this, stated with the estimate: 20%; at least 8.3-fold (0.92 log units) between middle value and limit.
By their numbers in this assay, from the lowest: compounds 1, 2 and 3 (each within the scatter of the next). At a limit, above all of these: compound 4.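

In this assay, ethyl in place of 4-iodophenyl on the amide-type nitrogen gives an at least 10-fold higher number from compound 1 to compound 4 (1.02 log units; beyond the scatter). The earlier steps, such as a 1.1-fold higher number from compound 1 to compound 2 (0.02 log units; within the scatter), exchanged only the group on an aromatic carbon and kept the ring that carries it, whereas this change removes the ring itself, and it is the only step among these four compounds that lies beyond the scatter. So far, then, the numbers barely respond to the iodo, nitro and 4-butylcyclohexyl exchanges but respond strongly to this replacement, and the full size of the step remains unknown: the limit of > 100000 nM in this assay, at which 1 of the 4 values shown sits.

The change removes the iodo and the aromatic ring together and brings in a much smaller group, so the compounds shown cannot separate the loss of the ring from the loss of the iodo or from the arrival of ethyl. On these data alone, it also remains open where a plain phenyl, which would keep the ring without the iodo, or a longer chain such as hexyl, would fall on this nitrogen.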